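A few compounds are considered here, and "the series" means these few. Any claim that something is new, unique, unknown or untested is made for them only; others in the source may bear on it.

Three measured compounds share one core and differ only in the chain and the ring that hang from the amide. Compound 1 `CC(C)(C)c1cc(/C=C/C(=O)NCC2CCN(Cc3ccccc3)CC2)cc(C(C)(C)C)c1O`, compound 2 `CC(C)(C)c1cc(/C=C/C(=O)NCCC2CCN(Cc3ccccc3)CC2)cc(C(C)(C)C)c1O` and compound 3 `CC(C)(C)c1cc(/C=C/C(=O)NCCC2CCN(Cc3cccc(F)c3)CC2)cc(C(C)(C)C)c1O` were each tested in an assay on isolated protein for inhibition of Amine oxidase [flavin-containing] A (Homo sapiens), read by fluorescence, with stated times of 15 min and 20 min; a higher number here means a weaker inhibitor, a lower number a stronger inhibitor. Compound 1 gives 48400 nM, compound 2 gives 62300 nM and compound 3 gives 58400 nM. Compound 3 thus stands second highest of the three numbers, with compound 2 nearest and compound 1 furthest, and both gaps fall within the scatter, so these three compounds cannot be told apart on the numbers shown.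

Compound 4 `CC(C)(C)c1cc(/C=C/C(=O)NCCC2CCN(Cc3ccccc3Cl)CC2)cc(C(C)(C)C)c1O` is the compound yet to be measured. The change from compound 3 to compound 4 is 2-chlorophenyl in place of 3-fluorophenyl on a saturated chain carbon bound to an amine nitrogen in a ring. Going by the values given here, one measured step bears on this, because it also alters the substitution of the same aromatic ring: a 1.1-fold lower number from compound 2 to compound 3 (0.03 log units; within the scatter). Among the compounds with values here, that step did not move the number beyond the scatter, and nothing among the measured compounds shows what chlorine on this ring does, so the expectation for compound 4 rests on that single step alone. Compound 4 is therefore expected to sit close to compound 3, as a step of a 1.1-fold lower number from compound 3 to compound 4 (0.03 log units; within the scatter), with no movement beyond the scatter foreseen in either direction. The estimate for compound 4 in this assay is 55000 nM, with a range from 25000 nM to 120000 nM.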

Compound 4, half-maximal inhibitory concentration: 72100 nM
For compound 4 the middle estimate is 1.3-fold (0.12 log units) below the measured one; low and high end bracket the measured number.
By their numbers in this assay, from the lowest: compounds 1, 3, 2 and 4 (each within the scatter of the next).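

In this assay, exchanging 3-fluorobenzyl for 2-chlorobenzyl gives a 1.2-fold higher number from compound 3 to compound 4 (0.09 log units; within the scatter), and putting chlorine on the unsubstituted benzyl ring gives a 1.2-fold higher number from compound 2 to compound 4 (0.06 log units; within the scatter). Going by these compounds alone, this is the first view of chlorine at this place, and it shows that neither step carries the number beyond the scatter, so the three compounds with the two-carbon chain, whether the ring bears no halogen, fluorine or chlorine, cannot be told apart here. No other measurement is at hand to account for how closely these numbers sit together.

The exchange of 3-fluorophenyl for 2-chlorophenyl alters both the halogen and the place it occupies on the ring, so the compounds shown cannot separate those two changes, and 3-chlorophenyl and 2-fluorophenyl would be the groups to tell them apart. From the compounds shown here alone, it also remains open whether any substituent on this ring can shift the number beyond the scatter, for instance a methoxy group, a carboxylic acid or an amine, since only hydrogen, fluorine and chlorine appear on it so far.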